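Hydroxy-fluoro phenyl variant of a triazolyl pyridine urea

The compounds below may be only part of what the source reports. "The series", "measured", "known", "first", "only" and "open" are said of these compounds alone.

Compounds measured so far in a functional assay on NCI-H460 cells (Homo sapiens) for cytotoxicity, read by MTT assay, with a stated time of 72 h; a lower number here means a stronger inhibitor, a higher number a weaker inhibitor:

compound 1, `CN(C)CCn1cnnc1-c1cc(Oc2ccc(NC(=O)N/N=C/c3c(Cl)cccc3Cl)cc2F)ccn1`, 350 nM
compound 2, `CN(C)CCn1cnnc1-c1cc(Oc2ccc(NC(=O)N/N=C/c3ccccc3)cc2F)ccn1`, 1780 nM
compound 3, `Cn1ncnc1-c1cc(Oc2ccc(NC(=O)N/N=C/c3ccccc3)cc2F)ccn1`, 52200 nM

Compound 2 holds the second highest of the three numbers. Its nearest neighbour is compound 1, which differs only in the aryl group on the carbon with a double bond to nitrogen; here the data show a 5.1-fold higher number from compound 1 to compound 2 (0.71 log units; beyond the scatter). Compound 3 differs from compound 2 only on the aromatic carbon of the shared core, and that change gave a 29-fold higher number from compound 2 to compound 3 (1.47 log units; beyond the scatter).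

The new compound 4, `CN(C)CCn1cnnc1-c1cc(Oc2ccc(NC(=O)N/N=C/c3ccc(O)c(F)c3)cc2F)ccn1`, keeps the core of compound 2 unchanged and alters only the aryl group: 3-fluoro-4-hydroxyphenyl in place of phenyl on a carbon with a double bond to nitrogen. The step from compound 1 to compound 2 is the one that bears on this change, since it too alters the ring on the carbon with a double bond to nitrogen; it was modest in size. The step to compound 3 concerns a different position and says nothing direct about compound 4. Given that substituents on this ring have moved the number modestly, a modest step is expected for compound 4, more likely toward a lower number than a higher one, and the estimate is 1000 nM with a range from 300 nM to 3500 nM, which corresponds to an expected 1.8-fold lower number from compound 2 to compound 4 (0.25 log units; within the scatter).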

Compound 4, half-maximal inhibitory concentration: 2620 nM
Compound 4: middle estimate off by 2.6-fold (0.42 log units), on the low side; the measured number falls inside the stated range.
By their numbers in this assay, from the lowest: compound 1; then compounds 2 and 4 (each within the scatter of the next); then compound 3.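

In this assay, the 3-fluoro-4-hydroxyphenyl group on the carbon with a double bond to nitrogen cannot be told apart from plain phenyl, the step being a 1.5-fold higher number from compound 2 to compound 4 (0.17 log units; within the scatter), so this ring can gain a hydroxy group and a fluorine without a change that stands clear of the scatter. The comparison with the 2,6-dichlorophenyl group gives a 7.5-fold higher number from compound 1 to compound 4 (0.87 log units; beyond the scatter), which shows that a substituted ring at this position does not by itself reproduce the step seen with compound 1, and that among the three rings shown only the 2,6-dichlorophenyl group stands apart. Nothing available accounts for the difference between these two substituted rings.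

The compounds shown leave open whether a single chlorine on this ring would keep part of the step seen with the two chlorines, and whether a methoxy group or an amine in place of the hydroxy group would shift the number. They also leave open whether the large step from the shared core of compound 2 to that of compound 3 would hold with the 2,6-dichlorophenyl group in place.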